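Replacing a benzylamino with a dimethylaminoethyl amine

The source may hold more compounds than are shown below. What is called first, only, known or untested is meant among the compounds shown, and "the series" means these compounds.

Compound 2 `Nc1nc(C(F)(F)F)cc2c1[nH]c(=O)n2Cc1ccc(NCc2ccccc2)nc1` sits at the low end of the three values in hand. In an in vitro ADME assay on microsomes from liver (Homo sapiens) for pharmacokinetics (a higher number here means faster removal of the compound, a lower number slower removal), compound 2 gives only a limit, < 8 mL.min-1.g-1, and no number. Compound 1 `CCN(CC)CCN(C)c1ccc(Cn2c(=O)[nH]c3c(N)nc(C(F)(F)F)cc32)cn1` gives 24 mL.min-1.g-1 and compound 3 `CN1CCN(CCN(C)c2ccc(Cn3c(=O)[nH]c4c(N)nc(C(F)(F)F)cc43)cn2)CC1` gives 25 mL.min-1.g-1; the change a 1.0-fold higher number from compound 1 to compound 3 (0.02 log units; within the scatter) stays within the scatter. Compound 4 `CN(C)CCN(C)c1ccc(Cn2c(=O)[nH]c3c(N)nc(C(F)(F)F)cc32)cn1` differs from compound 2 by (2-(dimethylamino)ethyl)(methyl)amino in place of benzylamino on an aromatic carbon. The closest measured steps are an at least 3.0-fold lower number from compound 1 to compound 2 (0.47 log units; beyond the scatter) and an at least 3.1-fold higher number from compound 2 to compound 3 (0.49 log units; beyond the scatter), each carrying the same core between a benzylamino and an alkylamino side chain. Compound 4 carries a smaller alkylamino than either, so the step is expected to be at least modest and upward, an at least 2.5-fold higher number from compound 2 to compound 4 (0.39 log units; beyond the scatter). Compound 4 is therefore expected to give about 20 mL.min-1.g-1, between 10 mL.min-1.g-1 and 40 mL.min-1.g-1.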

Compound 4, intrinsic clearance in microsomes: 16 mL.min-1.g-1
Beside the measured number, compound 4's estimate is 1.3-fold (0.10 log units) above it; measured number inside the range.
By their numbers in this assay, from the lowest: compounds 4, 1 and 3 (each within the scatter of the next). At a limit, below all of these: compound 2.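

In this assay, dimethylamino at the end of the side chain gives a number that cannot be told apart from those of the two larger amines: a 1.5-fold lower number from compound 1 to compound 4 (0.18 log units; within the scatter) and a 1.6-fold lower number from compound 3 to compound 4 (0.19 log units; within the scatter). Against benzylamino, the step is an at least 2.0-fold higher number from compound 2 to compound 4 (0.30 log units; that floor lies within the scatter), so this side chain leaves less of a demonstrated gap than the other two did. Compound 2 gives a limit, not a number: the limit of < 8 mL.min-1.g-1 in this assay, at which 1 of the 4 values shown sits.

On these data alone, whether a morpholine, a primary amine or a longer chain in place of the dimethylaminoethyl side chain would shift the number stays open.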